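Pyrazole Attachment Point in a Tetrahydroquinoline Urea Series

A few compounds are considered here, and "the series" means these few. Any claim that something is new, unique, unknown or untested is made for them only; others in the source may bear on it.

Compound 1 `CNC(=O)N1CCCc2ccc(NC(=O)c3ccc(-c4cc[nH]n4)cc3)cc21` gives 550 nM in a functional assay on MV4-11 cells (Homo sapiens) for antiproliferative activity, with a stated time of 6 days; a higher number here means a weaker inhibitor, a lower number a stronger inhibitor.
Compound 2 `CNC(=O)N1CCCc2ccc(NC(=O)c3ccc(-c4ccn(C)n4)cc3)cc21` gives 830 nM in this assay.
Compound 3 `CNC(=O)N1CCCc2ccc(NC(=O)c3cccc(-c4cnn(C)c4)c3)cc21` gives 1040 nM in this assay.

Compound 1 shows the lowest of the three numbers, yet the step of a 1.5-fold higher number from compound 1 to compound 2 (0.18 log units; within the scatter) lies within the scatter, and the values of compound 1 and compound 3 are likewise too close to be told apart. Compound 4 `CNC(=O)N1CCCc2ccc(NC(=O)c3ccc(-c4cn[nH]c4)cc3)cc21` differs from compound 1 in one place: 1H-pyrazol-4-yl in place of 1H-pyrazol-3-yl on an aromatic carbon. Among the measured compounds shown here, no measured pair isolates this change. Compound 3 does carry a pyrazol-4-yl, but it is methylated on nitrogen and sits on a different carbon of the benzamide ring, so it cannot be read as a single step from compound 1. For the measured compounds named here, the one step that is available, a 1.5-fold higher number from compound 1 to compound 2 (0.18 log units; within the scatter), alters the same pyrazole and stays within the scatter, so a move of the attachment point with the same atom count is expected to leave this assay essentially unchanged. The expected step of a 1.2-fold higher number from compound 1 to compound 4 (0.07 log units; within the scatter) is therefore within the scatter. Compound 4 is expected to give 650 nM, with a range from 300 nM to 1500 nM.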

Compound 4, half-maximal inhibitory concentration: 870 nM
Compound 4: the middle estimate sits 1.3-fold (0.13 log units) below what was measured; the range from low to high includes it.
By their numbers in this assay, from the lowest: compounds 1, 2, 4 and 3 (each within the scatter of the next).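

On the aromatic carbon para to a large group, the exchange of 1H-pyrazol-3-yl for 1H-pyrazol-4-yl now has a direct reading in this assay: a 1.6-fold higher number from compound 1 to compound 4 (0.20 log units; within the scatter), so the two attachment points cannot be told apart by this read-out. The comparison with the methylated pyrazole gives the same picture, at a 1.0-fold higher number from compound 2 to compound 4 (0.02 log units; within the scatter), and so the three pyrazoles on this carbon remain indistinguishable in this assay. No independent measurement bears on these results, and they offer no explanation of them.

The compounds shown leave open whether an amine or a carboxylic acid in place of the pyrazole on this carbon would give a step beyond the scatter. They also leave open how 1-methyl-1H-pyrazol-4-yl would read on this same carbon.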